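A Smaller Acyl Group on the Macrolide Side Chain

The source may report more compounds than this note shows. Statements on the series, on what has been measured and on what is new or still open speak of the compounds shown alone.

Compound 1 `CC[C@H]1OC(=O)[C@H](C)[C@@H](O[C@H]2C[C@@](C)(OC)[C@@H](O)[C@H](C)O2)[C@H](C)[C@@H](O[C@@H]2O[C@H](C)C[C@H](N(C)C)[C@H]2O)[C@](C)(O)C[C@@H](C)CN(CCCNC(=O)C2CCC2)[C@H](C)[C@@H](O)[C@]1(C)O` gives 2.31 in a physicochemical assay for lipophilicity, read by HPLC, measured as chromatographic lipophilicity, at pH 7.4 (a higher number here means a more lipophilic compound, a lower number a more polar compound), which places it second highest among the three measured compounds. Compound 3 `CCC(=O)NCCCO[C@@H]1[C@@H](C)N(C)C[C@H](C)C[C@@](C)(O)[C@H](O[C@@H]2O[C@H](C)C[C@H](N(C)C)[C@H]2O)[C@@H](C)[C@H](O[C@H]2C[C@@](C)(OC)[C@@H](O)[C@H](C)O2)[C@@H](C)C(=O)O[C@H](CC)[C@@]1(C)O` gives 2.74 in this assay, a value beyond the scatter above compound 1, while compound 2 `CC[C@H]1OC(=O)[C@H](C)[C@@H](O)[C@H](C)[C@@H](O[C@@H]2O[C@H](C)C[C@H](N(C)C)[C@H]2O)[C@](C)(O)C[C@@H](C)CN(C)[C@H](C)[C@@H](O)[C@]1(C)O` gives 1.35, far below it. Compound 4 `CCC(=O)NCCCN1C[C@H](C)C[C@@](C)(O)[C@H](O[C@@H]2O[C@H](C)C[C@H](N(C)C)[C@H]2O)[C@@H](C)[C@H](O[C@H]2C[C@@](C)(OC)[C@@H](O)[C@H](C)O2)[C@@H](C)C(=O)O[C@H](CC)[C@@](C)(O)[C@H](O)[C@H]1C` has not yet been measured. It differs from compound 1 as follows: ethyl in place of cyclobutyl on a carbonyl carbon. Within the data shown here, no measured pair in this set shows the same change, so the step is expected from the structures alone. The account anticipates a modest downward step, near the edge of the scatter, and estimates compound 4 at 1.95, within 1.6 to 2.3, which implies an expected step of a number 0.36 log units lower from compound 1 to compound 4 (beyond the scatter).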

Compound 4, distribution coefficient: 1.86
Estimate against measurement, compound 4: 0.09 log units above, and the stated range covers the measured number.
By their numbers in this assay, from the lowest: compound 2; then compound 4; then compound 1; then compound 3.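

Ethyl in place of cyclobutyl on a carbonyl carbon, whose other neighbour is an amide-type nitrogen, gives the first step read at this position: in this assay it is a number 0.45 log units lower from compound 1 to compound 4 (beyond the scatter), a modest change. The acyl group at this place therefore registers in the read-out, although a single pair cannot set a trend. Nothing available here accounts for the size of this step. Going by these compounds, whether a longer chain, a phenyl ring or an amine on this carbonyl carbon would move the number further remains open. So does whether the same exchange would give a similar step in compound 3.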